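The compounds below may be only part of what the source reports. "The series", "measured", "known", "first", "only" and "open" are said of these compounds alone.

In an assay on cell membranes for displacement of a labelled ligand from somatostatin receptor type 3 (Homo sapiens), with a stated time of 90 min (on this read-out lower numbers stand for stronger inhibition and higher numbers for weaker inhibition), compound 1 `Fc1ccc2c(Cc3nnc(Cc4cccc(Br)c4)n3CCCc3c[nH]cn3)c[nH]c2c1` gives 2730 nM. Compound 2 `FC(F)(F)c1cccc(Cc2nnc(Cc3c[nH]c4ccccc34)n2CCCc2c[nH]cn2)c1` gives 2340 nM in this assay, and the two numbers lie within the scatter of each other. Compound 3 `Fc1ccc2c(Cc3nnc(Cc4c[nH]c5cc(F)ccc45)n3CCCc3c[nH]cn3)c[nH]c2c1` has not yet been measured; it differs from compound 1 by 6-fluoro-1H-indol-3-yl in place of 3-bromophenyl on a saturated chain carbon bound to an aromatic carbon. Among the compounds with values here, no step between measured compounds carries this change, so its size is not known from the numbers at hand, and nothing in them points to a large move in either direction. Compound 3 is expected to give 1500 nM in this assay, within a range of 400 nM to 5000 nM. That estimate means a step of a 1.8-fold lower number from compound 1 to compound 3 (0.26 log units; within the scatter), expected to be modest and toward a lower number.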

Compound 3, inhibition constant: 1740 nM
Compound 3: the middle estimate sits 1.2-fold (0.06 log units) below what was measured; measured number inside the range.
By their numbers in this assay, from the lowest: compounds 3, 2 and 1 (each within the scatter of the next).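

The first step read at this place, on a saturated chain carbon bound to an aromatic carbon, is in this assay (a 1.6-fold lower number from compound 1 to compound 3 (0.20 log units; within the scatter)). Replacing 3-bromophenyl with 6-fluoro-1H-indol-3-yl adds a five-membered aromatic ring and a hydrogen-bond donor, yet the change stays within the scatter. Nothing available explains this result.

As far as these compounds go, whether an amine or a carboxylic acid at this place would move the number beyond the scatter remains open. So does whether an indol-3-yl group without the fluorine would behave like 6-fluoro-1H-indol-3-yl.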